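A few compounds are considered here, and "the series" means these few. Any claim that something is new, unique, unknown or untested is made for them only; others in the source may bear on it.

Compound 1 `CC(=O)N[C@@H](CO)[C@H](O)/C=C/c1ccccc1`: no result reported
Compound 2 `CC(=O)N[C@@H](CO)[C@H](O)/C=C/c1ccc(-c2ccccc2)cc1`: no result reported
Compound 3 `CCCCCCCCc1ccc(/C=C/C(=O)[C@H](CO)NC(C)=O)cc1`: 70000 nM

This small set offers very little to measure against. For the measured compounds named here, in a functional assay on PC-12 cells (Rattus norvegicus) for antiproliferative activity, read by resazurin assay, with a stated time of 24 h (a higher number here means a weaker inhibitor, a lower number a stronger inhibitor), compound 3 gives 70000 nM, and that is the only number available. Compounds 1 and 2 have no reported result, so compound 3 cannot be ranked against either of them. Its value is a single reference point, not a place on a scale.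

The compound still awaiting measurement is compound 4 `CC(=O)N[C@@H](CO)C(=O)/C=C/c1ccc(-c2ccccc2)cc1`. It keeps the rest of compound 3 and changes one group: phenyl in place of octyl on an aromatic carbon. Put simply, this is phenyl in place of octyl on an aromatic carbon, para to a large group.

Going by the values given here, no measured pair of compounds shows what this exchange does in this assay, so the data give no direct guide to its size or direction. The forecast therefore starts from compound 3 at 70000 nM and expects no shift beyond the usual scatter of repeated measurements, although a real move either way remains possible. The estimated change is a 1.2-fold lower number from compound 3 to compound 4 (0.07 log units; within the scatter). With so little evidence, the expected range is kept wide. For compound 4 the estimated value is 60000 nM, expected to fall between 20000 nM and 170000 nM.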

Compound 4, half-maximal inhibitory concentration: 59000 nM
Estimate against measurement, compound 4: 1.0-fold (0.01 log units) above, within the range that was stated.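

In this assay, exchanging octyl for phenyl gives a 1.2-fold lower number from compound 3 to compound 4 (0.07 log units; within the scatter), so the two compounds cannot be told apart in this test. For the compounds shown here, this is the first direct look at this position, on an aromatic carbon para to a large group: an open chain and a six-membered aromatic ring, both carbon only and both uncharged, give readings that match within normal repeat variation, although this rests on a single pair of compounds. No supporting measurement is available to explain why the exchange leaves the reading where it is.

Compounds 1 and 2 have no reported result, so any comparison that involves them cannot be read, including the one between the hydroxyl of compound 2 and the carbonyl of compound 4. The compounds shown also leave open whether an amine, a carboxylic acid or a chain longer than octyl at this same position would give a clearly different number, since both groups compared here contain only carbon and neither carries a charge.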